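Amino for Chloro: an Expected Step in Growth Inhibition

This account rests on a few compounds, and the source may have more. Where it says the series, first, only, none or still open, it means among the compounds named here.

Of the compounds shown here, three have been tested in a functional assay on NCI-H460 cells (Homo sapiens) for cytotoxicity, read by sulforhodamine B assay, with a stated time of 48 h; a lower number here means a stronger inhibitor of growth, a higher number a weaker inhibitor of growth. Compound 3 `ClCc1ccc(Cn2cnc3c(Cl)nc(Cl)nc32)cc1` gives 4900 nM, compound 1 `Nc1nc(Cl)c2ncn(Cc3ccc(CCl)cc3)c2n1` gives 9950 nM, and compound 2 `ClCc1cccc(Cn2cnc3c(Cl)nc(Cl)nc32)c1` gives 6310 nM. Compounds 2 and 3 are built from the same atoms joined differently; the difference between the two cores is not broken down here, and their values lie within the scatter of each other. Compound 3 becomes compound 1 through one change, (amino in place of chloro on an aromatic carbon), which produced a 2.0-fold higher number from compound 3 to compound 1 (0.31 log units; beyond the scatter).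

Compound 4 `Nc1nc(Cl)c2ncn(Cc3cccc(CCl)c3)c2n1` has not been measured. It arises from compound 2 by the same change, (amino in place of chloro on an aromatic carbon). The expectation for compound 4 rests on the step from compound 3 to compound 1, a 2.0-fold higher number from compound 3 to compound 1 (0.31 log units; beyond the scatter). The estimated step is a 2.0-fold higher number from compound 2 to compound 4 (0.30 log units; within the scatter). Compound 4 is therefore expected to give about 12600 nM, likely between 6300 nM and 25000 nM.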

Compound 4, concentration for total growth inhibition: 15900 nM
The estimate for compound 4 lay 1.3-fold (0.10 log units) below the measured number, within the range that was stated.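

In this assay, amino in place of chloro gave a 2.5-fold higher number from compound 2 to compound 4 (0.40 log units; beyond the scatter), so the same change again came with weaker growth inhibition, as it did on the core of compound 3. The two steps agree in direction and do not differ beyond the scatter, so the change carried over between these two cores with much the same size: the same change on two cores in this assay, a 2.0-fold higher number (0.31 log units; beyond the scatter) from compound 3 to compound 1 and a 2.5-fold higher number (0.40 log units; beyond the scatter) from compound 2 to compound 4, 1.2-fold (0.09 log units) apart, within the scatter of two such steps. Among these compounds, this is only two pairs of closely related compounds, so it does not show why the number rises, nor that the step would hold on a more different core.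

Going by these compounds, whether a methylamino group or a hydroxyl group in the same place would give a similar step remains open. So does the effect of replacing the chloromethyl group with a longer chain.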